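A few compounds are considered here, and "the series" means these few. Any claim that something is new, unique, unknown or untested is made for them only; others in the source may bear on it.

Of the compounds shown here, three that share one core have been tested in a functional assay on U-87MG ATCC cells for antiproliferative activity against U-87 MG (Homo sapiens), read by MTT assay, with a stated time of 48 h, tested at 50 uM; on this read-out lower numbers stand for a stronger effect and higher numbers for a weaker effect at the one concentration tested. Compound 1 `COc1ccc(-c2nc(C)c(C(=O)CSc3nc(N)c(C#N)c(-c4ccc(Cl)cc4)n3)s2)cc1` gives 23.1%. Compound 2 `COc1ccc(-c2nc(C)c(C(=O)CSc3nc(N)c(C#N)c(-c4ccccc4)n3)s2)cc1` gives 16.5%, the second highest of the three numbers; its nearest neighbour is compound 3 `COc1ccc(-c2nc(C)c(C(=O)CSc3nc(N)c(C#N)c(-c4ccc(OC)cc4)n3)s2)cc1`, which gives 13%, and its furthest is compound 1. The step of a number 6.6 percentage points lower from compound 1 to compound 2 (within the scatter) and the step of a number 3.5 percentage points lower from compound 2 to compound 3 (within the scatter) both lie within the scatter, while the step of a number 10.1 percentage points lower from compound 1 to compound 3 (beyond the scatter) is a modest change beyond it. Compound 4 `Cc1nc(-c2ccc(Cl)cc2)sc1C(=O)CSc1nc(N)c(C#N)c(-c2ccccc2)n1` has not yet been measured. Its difference from compound 2 is chloro in place of methoxy on an aromatic carbon. Among the compounds with values here, this swap sits on a different ring of the shared core from the one that varies among compounds 1, 2 and 3, so no measured step tests it directly; the closest hint is the step from compound 1 to compound 3, where chloro rather than methoxy went with a modestly higher number. The expected step of a number 3.5 percentage points higher from compound 2 to compound 4 (within the scatter) is therefore small, upward if anything, and may stay within the scatter. Compound 4 is estimated at 20%, between 10% and 32%.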

Compound 4, a percentage reported as activity, at one concentration (the size of the read-out at that concentration, not a potency): 15.2%
The estimate for compound 4 lay 4.8 percentage points above the measured number; the measured number falls inside the stated range.
By their numbers in this assay, from the lowest: compounds 3, 4, 2 and 1 (each within the scatter of the next, the first and the last beyond it).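

Compound 4 tests the change from 4-methoxyphenyl to 4-chlorophenyl directly, on the ring that stays the same in compounds 1, 2 and 3, and in this assay the step is a number 1.3 percentage points lower from compound 2 to compound 4 (within the scatter). At this place, para to a large group, compound 2 and compound 4 therefore cannot be told apart, so this swap shows no measurable effect on the read-out here. Set beside the same swap elsewhere in the molecule, the result gives no firm sign that the two places respond differently: the same change on two cores in this assay, a number 10.1 percentage points lower (beyond the scatter) from compound 1 to compound 3 and a number 1.3 percentage points higher (within the scatter) from compound 4 to compound 2, 11.4 percentage points apart, within the scatter of two such steps.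

As far as these compounds go, what an amine, a carboxylic acid or a longer alkoxy chain would do at this place remains open. The compounds shown are compared at a single concentration, so how their potencies compare also remains open.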